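Methoxy in place of methyl on the benzamide ring

A few compounds are considered here, and "the series" means these few. Any claim that something is new, unique, unknown or untested is made for them only; others in the source may bear on it.

Measured so far:
compound 1 `O=C(NCc1ccc(CNS(=O)(=O)c2ccccc2)cc1)c1ccc([N+](=O)[O-])cc1`, 100 nM
compound 2 `O=C(NCc1ccc(CNS(=O)(=O)c2ccccc2)cc1)c1c(Cl)cc(Cl)cc1Cl`, 10 nM
compound 3 `Cc1ccc(C(=O)NCc2ccc(CNS(=O)(=O)c3ccccc3)cc2)cc1`, 100 nM

In an assay on MDA-MB-231 cells for binding affinity to C-X-C chemokine receptor type 4 (Homo sapiens), read by immunofluorescence and microscopy, with stated times of 10 min and 30 min (on this read-out lower numbers stand for an effect already at smaller amounts and higher numbers for an effect only at larger amounts of compound), compound 3 gives 100 nM, level with compound 1 and together with it the highest of the three numbers; the step of a 10-fold higher number from compound 2 to compound 3 (1.00 log units; beyond the scatter) is the only one beyond the scatter, while no change at the digits printed from compound 1 to compound 3 (within the scatter) stays within it. Compound 4 `COc1cccc(C(=O)NCc2ccc(CNS(=O)(=O)c3ccccc3)cc2)c1` differs from compound 3 by 3-methoxyphenyl in place of 4-methylphenyl on a carbonyl carbon. For the measured compounds named here, the steps that bear on it, no change at the digits printed from compound 1 to compound 3 (within the scatter) and a 10-fold higher number from compound 2 to compound 3 (1.00 log units; beyond the scatter), show that exchanging the aromatic group on the carbonyl carbon can leave the number unchanged or move it by a modest amount. Compound 4 is therefore expected to give 100 nM, within 30 nM to 300 nM, which means an expected step of no change at the digits printed from compound 3 to compound 4 (within the scatter).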

Compound 4, effective concentration (reported as EC, without a stated level of effect): > 1000 nM
Compound 4: no number, only a limit; the forecaster's own chance of this, stated with the estimate: 5%; middle value at least 10-fold (1.00 log units) away from the limit.
By their numbers in this assay, from the lowest: compound 2; then compounds 1 and 3 (each within the scatter of the next). At a limit, above all of these: compound 4.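

Compound 4 gives only a limit, not a number, in this assay: the limit of > 1000 nM in this assay, at which 1 of the 4 values shown sits.

Compound 1 and compound 3 had shown no change on exchanging this aromatic group, but this position does not accept every such exchange. 3-methoxyphenyl in place of 4-methylphenyl on the carbonyl carbon gives an at least 10-fold higher number from compound 3 to compound 4 (1.00 log units; beyond the scatter), with an at least 10-fold higher number from compound 1 to compound 4 (1.00 log units; beyond the scatter) and an at least 100-fold higher number from compound 2 to compound 4 (2.00 log units; beyond the scatter).

Going by these compounds, whether this follows from the methoxy group itself or from its place on the ring stays open, as both differ here. On these data alone, how an amine or a carboxylic acid on this aromatic group would behave also stays open.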